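The compounds below may be only part of what the source reports. "The series", "measured", "known", "first", "only" and "open" are said of these compounds alone.

In a functional assay on HCT-116 cells (Homo sapiens) for inhibition (a higher number here means a weaker inhibitor, a lower number a stronger inhibitor), compound 3 `CC(=O)Oc1ccc(/C=C/c2ccc3ccccc3c2)cc1` gives > 5000 nM, which is a limit of the assay and not a number. Compound 1 `COCCOc1cc(/C=C/c2ccc3ccccc3c2)ccc1OC` gives > 5000 nM, also a limit. Going by the values given here, compound 2 `COCCOc1cc(/C=C\c2ccc3ccccc3c2)ccc1OC` gives 2990 nM, the only real number so far. Compound 4 `Oc1ccc(/C=C/c2ccc3ccccc3c2)cc1` differs from compound 3 by a single change, (hydrogen in place of acetyl on an oxygen on an aromatic ring), which reads as acetoxy to hydroxy. Among the compounds with values here, the one measured step, an at least 1.6-fold lower number from compound 1 to compound 2 (0.22 log units; that floor lies within the scatter), offers little guidance because of the fact that compounds 1 and 2 differ only in the configuration as drawn, and no measured step involves this oxygen. Only a small move towards lower numbers is therefore expected, and the expected step is an at least 1.2-fold lower number from compound 3 to compound 4 (0.09 log units; that floor lies within the scatter). For compound 4 the estimate is 4000 nM, with an expected range from 1500 nM to 9000 nM.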

Compound 4, half-maximal inhibitory concentration: 4060 nM
For compound 4 the middle estimate is 1.0-fold (0.01 log units) below the measured one, within the range that was stated.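

In this assay compound 3 gives > 5000 nM and this is a limit of the assay, not a number. Going from acetoxy to hydroxy on this oxygen gives an at least 1.2-fold lower number from compound 3 to compound 4 (0.09 log units; that floor lies within the scatter) and so yields a real number at this place for the first time among these compounds. Only a floor of that step can be read, because the acetoxy side of the comparison sits at a limit: the limit of > 5000 nM in this assay, at which 2 of the 4 values shown sit.

The compounds shown leave open what a methyl group or a longer carbon chain on this oxygen would give. They also leave open whether any group here moves the number beyond the scatter.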